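A Dichlorophenyl Replaces the Fluoromethylphenyl on the Propyl Chain

The compounds below may be only part of what the source reports. "The series", "measured", "known", "first", "only" and "open" are said of these compounds alone.

Compound 1 `Cc1ccc(CCCOC(=O)N(c2ccccc2)C2CN3CCC2CC3)cc1F` gives 130 nM in an assay on CHO cells for displacement of a labelled ligand from muscarinic acetylcholine receptor M5 (Homo sapiens), read by scintillation counting, with a stated time of 2 h; a lower number here means a stronger inhibitor, a higher number a weaker inhibitor. Among the three measured compounds it stands second highest: compound 2 `Cc1ccc(COC(=O)N(c2ccccc2)C2CN3CCC2CC3)cc1F` gives 30 nM, and compound 3 `COc1ccc(COC(=O)N(c2ccccc2)C2CN3CCC2CC3)cc1` gives 470 nM. The change from compound 1 to compound 4 `O=C(OCCCc1ccc(Cl)c(Cl)c1)N(c1ccccc1)C1CN2CCC1CC2` is 3,4-dichlorophenyl in place of 3-fluoro-4-methylphenyl on a saturated chain carbon, three bonds along the chain from an oxygen next to a carbonyl group. Within the data shown here, no measured step exchanges these two aryl groups. Among the measured compounds shown here, the only step that bears on aryl substitution is a 16-fold higher number from compound 2 to compound 3 (1.19 log units; beyond the scatter), which was large but involved a different pair of groups on a shorter chain. Since both aryl groups here carry two small substituents and no donors or acceptors, the author expects a step of a 1.3-fold lower number from compound 1 to compound 4 (0.11 log units; within the scatter), within the scatter. Compound 4 is therefore estimated at 100 nM, with a range from 30 nM to 400 nM.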

Compound 4, inhibition constant: 130 nM
Compound 4: the middle estimate sits 1.3-fold (0.11 log units) below what was measured; low and high end bracket the measured number.
By their numbers in this assay, from the lowest: compound 2; then compounds 1 and 4 (each within the scatter of the next); then compound 3.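

In this assay, 3,4-dichlorophenyl in place of 3-fluoro-4-methylphenyl on the propyl chain brings no change at the digits printed from compound 1 to compound 4 (within the scatter), so this position accepts this exchange. Among these compounds, the one earlier aryl step, a 16-fold higher number from compound 2 to compound 3 (1.19 log units; beyond the scatter), involved other groups on a shorter chain and gave no such reading for the propyl chain. No measurement offers an explanation for this result.

The compounds shown leave open whether the same exchange would hold on the shorter chain of compound 2. They also leave open how an amine or a carboxylic acid on the aryl ring, or a longer chain, would fare.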